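Swapping the pyrimidine substituents in an isoxazole thiourea series

The source may hold more compounds than are shown below. What is called first, only, known or untested is meant among the compounds shown, and "the series" means these compounds.

Compound 1 `COc1cc(Cl)nc(NC(=S)NC(=O)c2c(-c3ccc(Cl)cc3Cl)noc2C)n1`: 53.2%
Compound 2 `CSc1cc(C)nc(NC(=S)NC(=O)c2c(-c3ccc(Cl)cc3Cl)noc2C)n1`: 86.1%
Compound 3 `CSc1cc(C)nc2n/c(=N/C(=O)c3c(-c4ccc(Cl)cc4Cl)noc3C)sn12`: 75.2%

These three compounds share a core and were tested in a functional assay on the whole organism for inhibition, with Chenopodium ficifolium as the target, with a stated time of 72 h, tested at 100 mg/L; on this read-out lower numbers stand for less inhibition of growth and higher numbers for more inhibition of growth at the one concentration tested. Compound 2 stands highest of the three measured numbers: compound 3 gives 75.2% and compound 1 gives 53.2%, both lower than compound 2 by amounts beyond the scatter. Compound 4 `COc1cc(OC)nc(NC(=S)NC(=O)c2c(-c3ccc(Cl)cc3Cl)noc2C)n1` is not yet measured. It differs from compound 2 in one place: 4,6-dimethoxypyrimidin-2-yl in place of 4-methyl-6-(methylsulfanyl)pyrimidin-2-yl on an amide-type nitrogen.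

For the measured compounds named here, only one measured step bears on this change, the one from compound 1 to compound 2, which was a number 32.9 percentage points higher from compound 1 to compound 2 (beyond the scatter); there the pyrimidine substituents were also exchanged, and the number rose sharply. Moving away from the methyl and methylsulfanyl pair of compound 2 towards two methoxy groups, with compound 1 as the only methoxy-bearing point of comparison at 53.2%, a decrease is expected for compound 4, of the size a number 21.1 percentage points lower from compound 2 to compound 4 (beyond the scatter) in this assay. The estimate for compound 4 is therefore 65%, within a range from 40% to 88%.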

Compound 4, percent growth inhibition at one concentration: 78.6%
Compound 4: the middle estimate sits 13.6 percentage points below what was measured; measured number inside the range.
By their numbers in this assay, from the lowest: compound 1; then compounds 3, 4 and 2 (each within the scatter of the next, the first and the last beyond it).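

In this assay the pyrimidine on the amide-type nitrogen accepts more than one set of substituents: with 4,6-dimethoxypyrimidin-2-yl in place of 4-methyl-6-(methylsulfanyl)pyrimidin-2-yl, the numbers stay within the scatter of each other (a number 7.5 percentage points lower from compound 2 to compound 4 (within the scatter)). Methoxy groups on this pyrimidine therefore do not by themselves go with a low number, which compound 1 alone could not show. The single change of methoxy in place of chloro on an aromatic carbon gives a clear rise (a number 25.4 percentage points higher from compound 1 to compound 4 (beyond the scatter)), so among these compounds the low number of compound 1 goes with its chloro group.

Nothing measured here explains why chloro and methoxy differ on this pyrimidine. On these data alone, whether an amine or an ethoxy group in place of a methoxy group would keep the growth inhibition remains open.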